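Working notes: urea terminus change, compound 3 to compound 4

The source may hold more compounds than are shown below. What is called first, only, known or untested is meant among the compounds shown, and "the series" means these compounds.

Measured so far in a functional assay on HEK293 cells for agonist activity at Vasopressin V2 receptor (Homo sapiens), read by a luciferase reporter and cAMP accumulation; on this read-out higher numbers stand for an effect only at larger amounts of compound and lower numbers for an effect already at smaller amounts:
compound 1 `O=C(NCc1ccc(C(=O)N2CCCCc3ccccc32)c(F)c1)Nc1c(F)cccc1F` gives 180 nM
compound 2 `CCc1cc(C(=O)N2CCCCc3ccccc32)ccc1CNC(=O)Nc1c(F)cccc1F` gives 10 nM
compound 3 `Cc1cc(C(=O)N2CCCCc3ccccc32)ccc1CNC(=O)Nc1ccccc1` gives 130 nM

Compound 3 stands with the second highest number of the three. Its nearest neighbour is compound 1, whose number lies within the scatter of that of compound 3, so the two cannot be ordered on these data. Compound 2 stands well apart, with a number beyond the scatter below that of compound 3; this is the only separation that holds among the three.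

Compound 4 `Cc1cc(C(=O)N2CCCCc3ccccc32)ccc1CNC(=O)NCC(N)=O` is not yet measured in this assay. It differs from compound 3 in one place: carbamoylmethyl in place of phenyl on an amide-type nitrogen. Among the measured compounds shown here, no pair among the measured compounds shows this change, so no measured step can be drawn on. From the compounds shown here alone, all three measured compounds carry an aryl group on that urea nitrogen, and the one that stands apart, compound 2, keeps it; what happens when an aryl group is lost there is unknown from these numbers.

The expectation for the step from compound 3 to compound 4 in this assay is a move toward higher numbers, beyond the scatter, a 12-fold higher number from compound 3 to compound 4 (1.06 log units; beyond the scatter). Compound 4 is estimated at 1500 nM, within a range from 300 nM to 8000 nM.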

Compound 4, half-maximal effective concentration: 210 nM
Estimate against measurement, compound 4: 7.1-fold (0.85 log units) above; the measured number lies below the stated range.
By their numbers in this assay, from the lowest: compound 2; then compounds 3, 1 and 4 (each within the scatter of the next).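

In this assay, the urea terminus of this series proves not to depend on an aryl group in this pair: the step reads a 1.6-fold higher number from compound 3 to compound 4 (0.21 log units; within the scatter), so carbamoylmethyl in place of phenyl on an amide-type nitrogen gives no change that can be told from the scatter. Among the compounds shown here, all the earlier compounds carry an aryl group on this nitrogen, and they could not show that a group with no ring, with fewer heavy atoms and with a hydrogen-bond donor and acceptor that phenyl lacks, can stand here with the number unchanged within the scatter. Nothing available bears on why this swap leaves the number where it is.

This single pair leaves open how far the tolerance extends, for instance to a carboxylic acid or a primary amine at the end of the chain, to a plain methyl group, or to a longer chain carrying the same terminal carbamoyl. Also open, from the compounds shown here alone, is whether the same change on compound 2, at 10 nM, would likewise stay within the scatter, given the difluorophenyl group and ethyl substituent that compound carries.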